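The source may report more compounds than this note shows. Statements on the series, on what has been measured and on what is new or still open speak of the compounds shown alone.

Notes on the series. Among the measured compounds shown here, compound 1 `CCn1c(C(=O)NCCN)ccc1C(CC)(CC)c1ccc(OCCC(O)(CC)CC)c(C)c1` stands lowest of the three numbers measured so far: in an assay on cells for agonist activity at vitamin D3 receptor (Homo sapiens), with a stated time of 96 h (on this read-out higher numbers stand for an effect only at larger amounts of compound and lower numbers for an effect already at smaller amounts), compound 1 gives 156 nM. Compound 2 `C#CC(C)OC(=O)c1ccc(C(CC)(CC)c2ccc(OCCC(O)(CC)CC)c(C)c2)n1CC` gives 2650 nM, and compound 3 `CCOc1ccc(NC(=O)c2ccc(C(CC)(CC)c3ccc(OCCC(O)(CC)CC)c(C)c3)n2CC)cc1` gives 1630 nM. Both steps away from compound 1 changed the same end of the molecule and went the same way: a 17-fold higher number from compound 1 to compound 2 (1.23 log units; beyond the scatter), and a 10-fold higher number from compound 1 to compound 3 (1.02 log units; beyond the scatter). Compound 4 `CCOC(=O)C(CC(=O)OC)NC(=O)c1ccc(C(CC)(CC)c2ccc(OCCC(O)(CC)CC)c(C)c2)n1CC` makes a change of the same kind: a group of 11 heavy atoms (7 carbon, 4 oxygen; no ring) in place of a group of 3 heavy atoms (2 carbon, 1 nitrogen; no ring), on an amide-type nitrogen. Both measured steps that replace the 2-aminoethyl group bear on it and were large, so a large step towards a higher number is expected in this assay, estimated as a 9.6-fold higher number from compound 1 to compound 4 (0.98 log units; beyond the scatter). For compound 4 the expected value is 1500 nM, with a range from 500 nM to 5000 nM.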

Compound 4, half-maximal effective concentration: 21 nM
Compound 4: the middle estimate sits 71-fold (1.85 log units) above what was measured, and the stated range ends above it.
By their numbers in this assay, from the lowest: compound 4; then compound 1; then compounds 3 and 2 (each within the scatter of the next).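

The 2-aminoethyl group is not needed for a low number in this assay: the group of 11 heavy atoms, with 0 hydrogen-bond donors, gives a 7.4-fold lower number from compound 1 to compound 4 (0.87 log units; beyond the scatter). Size alone at this amide-type nitrogen therefore does not set the direction, and the same group also gives a 78-fold lower number from compound 3 to compound 4 (1.89 log units; beyond the scatter) and, in the change made on the carbonyl carbon, a 130-fold lower number from compound 2 to compound 4 (2.10 log units; beyond the scatter). No supporting measurement bears on why this group lowers the number. As far as these compounds go, it remains open which part of the entering group carries the step, and whether a carboxylic acid in place of either ester would hold it.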